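This account rests on a few compounds, and the source may have more. Where it says the series, first, only, none or still open, it means among the compounds named here.

Three compounds bearing a shared core have been examined in an assay on a protein complex for inhibition of CDK8/Cyclin C (Homo sapiens), with a stated time of 1 h, tested at 10 uM; on this read-out lower numbers stand for less inhibition and higher numbers for more inhibition at the one concentration tested (going by the name of the read-out). Compound 1 `CNC(=O)/C=C/c1ccncc1-c1ccc2ccccc2c1` gives 101% in this assay, compound 2 `CCOC(=O)/C=C/c1ccncc1-c1ccc2c(cnn2C)c1` gives 100%, and compound 3 `NNC(=O)CCc1ccncc1-c1ccc2ccccc2c1` gives 102%. Compound 3 thus holds the highest of the three numbers, but compound 1 and compound 2 both lie within the scatter of it, so the three are indistinguishable on this read-out. For the measured compounds named here, the one step that can be followed directly, a number 1 percentage points higher from compound 1 to compound 3 (within the scatter), shows that exchanging the chain on this carbon left the number essentially unchanged.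

Compound 4 `O=C(O)/C=C/c1ccncc1-c1ccc2ccccc2c1` differs from compound 3 by 2-carboxyethenyl in place of 2-(aminocarbamoyl)ethyl on an aromatic carbon. Going by the values given here, the only measured step that bears on this change is the one from compound 1 to compound 3, which was within the scatter, and all three measured compounds sit at the top of the read-out. Compound 4 is therefore expected to stay at a similar level, with a step of a number 6 percentage points lower from compound 3 to compound 4 (within the scatter) expected. The estimate for compound 4 in this assay is 96%, within a range from 82% to 104%.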

Compound 4, a percentage reported as inhibition, at one concentration (the size of the read-out at that concentration, not a potency): 102%
For compound 4 the middle estimate is 6 percentage points below the measured one; measured number inside the range.
By their numbers in this assay, from the lowest: compounds 2, 1, 3 and 4 (each within the scatter of the next).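

In this assay, 2-carboxyethenyl in place of 2-(aminocarbamoyl)ethyl on this aromatic carbon gives no change at the digits printed from compound 3 to compound 4 (within the scatter), and hydroxy in place of methylamino on the carbonyl carbon gives a number 1 percentage points higher from compound 1 to compound 4 (within the scatter). For the compounds shown here, the earlier compounds carried only an amide-type or ester end on this chain, so compound 4 is the first to show that a carboxylic acid at this place also leaves the number at the top of the read-out. No measurement available here accounts for this lack of response.

With all four compounds within the scatter at a single concentration, the read-out cannot rank these chains. From the compounds shown here alone, it remains open whether a simple amine, a longer chain or a plain methyl group at this place would lower the number.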